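Three related amides screened for cytotoxicity on human fibroblasts

This account rests on a few compounds, and the source may have more. Where it says the series, first, only, none or still open, it means among the compounds named here.

Compound 1, `CC(C)N(Cc1cccc(OCCCCCC(=O)O)c1)C(=O)c1ccc(-c2ccc3[nH]ccc3c2)cc1`: in an ADME assay on BJ cells (Homo sapiens) for cytotoxicity, read by CellTiter-Glo and resazurin assay, with a stated time of 72 h (on this read-out higher numbers stand for an effect only at larger amounts of compound and lower numbers for an effect already at smaller amounts), compound 1 gives > 26000 nM, which is a limit of the assay and not a number.
Compound 2, `CCOc1cccc(-c2ccc(C(=O)N(Cc3cccc(OCCCCCC(=O)O)c3)C(C)C)cc2)c1`: in this assay compound 2 gives > 20800 nM, again a limit.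
Compound 3, `CCOC(=O)CCCCCOc1cccc(CN(C(=O)c2ccc(-c3ccc4[nH]ccc4c3)cc2)C(C)C)c1`: in this assay compound 3 gives > 26000 nM, also a limit.

Compound 1 and compound 2 differ in one place: 3-ethoxyphenyl in place of 1H-indol-5-yl on an aromatic carbon. The step that the two limits leave unreadable from compound 1 to compound 2 cannot be sized, because the limit of > 20800 nM in this assay, at which 1 of the 3 values shown sits, and the limit of > 26000 nM in this assay, at which 2 of the 3 values shown sit, are where the two values sit. The cores of compound 1 and compound 3 differ by ethyl in place of hydrogen on an oxygen next to a carbonyl group; the step that the two limits leave unreadable from compound 1 to compound 3 is likewise not readable, since both values rest at the limit of > 26000 nM in this assay, at which 2 of the 3 values shown sit.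

Compound 4, `CCOC(=O)CCCCCOc1cccc(CN(C(=O)c2ccc(-c3cccc(OCC)c3)cc2)C(C)C)c1`, has not yet been tested in this assay. It differs from compound 3 by 3-ethoxyphenyl in place of 1H-indol-5-yl on an aromatic carbon, the same change, at the same place, that leads from compound 1 to compound 2. Resting on compound 3 sitting at the limit of > 26000 nM in this assay, at which 2 of the 3 values shown sit, the step that the limit leaves unreadable from compound 3 to compound 4 is expected to be small. Compound 4 is therefore estimated at 30000 nM, between 15000 nM and 70000 nM, and the assay will most probably again report only a limit.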

Compound 4, half-maximal effective concentration: > 22300 nM
Compound 4 gave a limit, no number; the forecaster's own chance of this, stated with the estimate: 85%; the middle value does not contradict the limit.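

In this assay compound 4 gives > 22300 nM as a limit of the assay and not a number. Neither the step from compound 3 to compound 4 nor the step from compound 2 to compound 4 can be sized: each joins two limits. The compounds shown leave open at what concentration any of the four reaches a half-maximal effect in this assay and whether either change alters it.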